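A few compounds are considered here, and "the series" means these few. Any claim that something is new, unique, unknown or untested is made for them only; others in the source may bear on it.

Working notes on the series. The three measured compounds share one core and differ only in the aromatic group carried on a saturated chain carbon bound to a carbonyl carbon. Compound 1 `Cc1ccccc1N/C(=N\C#N)N1CCN(C(=O)Cc2cccnc2)C(c2ccccc2)C1` carries pyridin-3-yl there, and in a functional assay for antagonist activity at P2X purinoceptor 7 (Rattus norvegicus), read by FLIPR and calcium flux (on this read-out higher numbers stand for weaker inhibition and lower numbers for stronger inhibition), compound 1 gives 390 nM. Compound 2 `Cc1ccccc1N/C(=N\C#N)N1CCN(C(=O)Cn2nccc2C)C(c2ccccc2)C1` carries 5-methyl-1H-pyrazol-1-yl, and in this assay compound 2 gives 560 nM. Compound 3 `Cc1ccccc1N/C(=N\C#N)N1CCN(C(=O)Cc2cccs2)C(c2ccccc2)C1` carries thiophen-2-yl, and in this assay compound 3 gives 150 nM, the lowest of the three numbers. The steps read a 1.4-fold higher number from compound 1 to compound 2 (0.16 log units; within the scatter), a 2.6-fold lower number from compound 1 to compound 3 (0.41 log units; beyond the scatter) and a 3.7-fold lower number from compound 2 to compound 3 (0.57 log units; beyond the scatter). Compound 4 `Cc1ccccc1N/C(=N\C#N)N1CCN(C(=O)Cc2c[nH]cn2)C(c2ccccc2)C1` is the next member; it differs from compound 3 by 1H-imidazol-4-yl in place of thiophen-2-yl on a saturated chain carbon bound to a carbonyl carbon. Among the measured compounds shown here, the steps that bear on this are the two swaps into thiophen-2-yl, both modest. Because a 2.6-fold lower number from compound 1 to compound 3 (0.41 log units; beyond the scatter) and a 3.7-fold lower number from compound 2 to compound 3 (0.57 log units; beyond the scatter) both ran lower into thiophen-2-yl, the move back out of thiophen-2-yl into another five-membered ring with two hetero atoms is expected to run the other way in this assay, by a modest amount. For compound 4 the expected step is a 4.0-fold higher number from compound 3 to compound 4 (0.60 log units; beyond the scatter), giving an estimate of 600 nM with a range from 200 nM to 2000 nM.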

Compound 4, half-maximal inhibitory concentration: 14000 nM
The estimate for compound 4 lay 23-fold (1.37 log units) below the measured number; the measured number lies above the stated range.
By their numbers in this assay, from the lowest: compound 3; then compounds 1 and 2 (each within the scatter of the next); then compound 4.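

In this assay, among the compounds shown here, this position proves far less tolerant than the earlier compounds suggested: a 93-fold higher number from compound 3 to compound 4 (1.97 log units; beyond the scatter), a 36-fold higher number from compound 1 to compound 4 (1.56 log units; beyond the scatter) and a 25-fold higher number from compound 2 to compound 4 (1.40 log units; beyond the scatter) are all large, whereas the earlier swaps were modest or within the scatter. For the compounds shown here, a five-membered aromatic ring with two hetero atoms does not in itself account for the loss, since compound 2 also carries one and stands at 560 nM, so the particular ring matters here, and 1H-imidazol-4-yl is the one group of the four that stands apart. Nothing available on these compounds explains the size of this step.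

Going by these compounds, whether the hydrogen-bond donor that enters with 1H-imidazol-4-yl goes with the loss stays open, and 1-methyl-1H-imidazol-4-yl at this place would bear on that. On these data alone, how a plain phenyl or a furan-2-yl would compare with thiophen-2-yl also stays open.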